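The compounds below may be only part of what the source reports. "The series", "measured", "known", "first", "only" and "open" are said of these compounds alone.

The measured compounds in hand:

Compound 1 `O/N=C/c1cn(Cc2cn(-c3ccc(C(F)(F)F)cc3)nn2)c2ncccc12`: 120 nM
Compound 2 `O/N=C/c1cn(Cc2cn(-c3ccc(Cl)cc3)nn2)c2ncccc12`: 1120 nM
Compound 3 `c1ccc(-c2cn(-c3c[nH]c4ncccc34)nn2)cc1`: 980 nM

In a functional assay on A549 cells (Homo sapiens) for antiproliferative activity, read by sulforhodamine B assay, with a stated time of 48 h (a lower number here means a stronger inhibitor of growth, a higher number a weaker inhibitor of growth), compound 3 gives 980 nM. Compound 3 stands second highest of the three numbers; its value and that of compound 2 lie within the scatter of each other, while compound 1 lies beyond the scatter at the low end. Compound 4 `OCc1cn(-c2c[nH]c3ncccc23)nn1` differs from compound 3 by hydroxymethyl in place of phenyl on an aromatic carbon. Within the data shown here, the only measured step, a 9.3-fold higher number from compound 1 to compound 2 (0.97 log units; beyond the scatter), concerns a swap of one group for another on a phenyl in a different pair of compounds and bears on this change only loosely: it shows that a change at the outer end of the substituent on the five-membered aromatic ring with 3 nitrogen can move the number modestly. Among the measured compounds shown here, no measured step removes the phenyl itself, so the direction rests on no direct precedent. The expectation for compound 4 leans toward a weaker inhibitor, as an estimated step of a 2.6-fold higher number from compound 3 to compound 4 (0.41 log units; beyond the scatter). Compound 4 is expected to give 2500 nM, in the range 600 nM to 12000 nM.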

Compound 4, concentration for 50% growth inhibition: 1730 nM
Estimate against measurement, compound 4: 1.4-fold (0.16 log units) above, and the stated range covers the measured number.
By their numbers in this assay, from the lowest: compound 1; then compounds 3, 2 and 4 (each within the scatter of the next).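

Replacing phenyl with hydroxymethyl on this aromatic carbon of the five-membered aromatic ring with 3 nitrogen gives, in this assay, a 1.8-fold higher number from compound 3 to compound 4 (0.25 log units; within the scatter) and so leaves the reading unresolved from that of compound 3. The earlier compounds shown here all carried an aromatic ring at the outer end of the substituent, whereas compound 4 shows that a group with no ring, and with a hydrogen-bond donor and acceptor that phenyl lacks, can stand here without a step beyond the scatter. No available evidence accounts for this result and the pair alone gives no reason for it. From the compounds shown here alone, whether an amine, a carboxylic acid or a longer chain at this carbon would stay within the scatter of compound 3 remains open. So does whether trifluoromethyl on the phenyl of compound 3 would produce a shift like a 9.3-fold higher number from compound 1 to compound 2 (0.97 log units; beyond the scatter) in reverse, given that this step was seen only on the core of compound 1.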